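A few compounds are considered here, and "the series" means these few. Any claim that something is new, unique, unknown or untested is made for them only; others in the source may bear on it.

Of the compounds shown here, three have been measured in a functional assay on MDA-MB-468 cells (Homo sapiens) for antiproliferative activity (on this read-out higher numbers stand for weaker inhibition and lower numbers for stronger inhibition), and each result is a limit rather than a number. Compound 1 `Nc1ccc(-c2nc3ccccc3s2)cc1Br` gives < 1 nM, which is a limit. Compound 2 `CC(=O)Nc1ccc(-c2nc3ccccc3s2)cc1C` gives > 10000 nM, which is also a limit. Compound 3 `CC(=O)Nc1ccc(-c2nc3ccccc3s2)cc1Cl` gives > 100 nM, again a limit, so its standing in this assay is known from one side only.

Compound 4 `CC(=O)Nc1ccc(-c2nc3ccccc3s2)cc1Br` keeps the acetamido group of compound 3 and changes one substituent, with bromo in place of chloro on an aromatic carbon.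

Among the measured compounds shown here, the one measured step that exchanges a group at this place is a step that the two limits leave unreadable from compound 2 to compound 3. That step offers no size to carry forward. For the measured compounds named here, no measured step exchanges chloro for bromo, and compound 1, the only bromo compound measured so far, has no acetamido group. The exchange is small in its counted atoms, so compound 4 is expected to stay close to the limit of compound 3, with no firm direction and a fair chance of another limit. The expected change is a step that the limit leaves unreadable from compound 3 to compound 4, which is an estimate. For compound 4 the estimated value is 250 nM. The expected range for compound 4 runs from 50 nM to 3000 nM.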

Compound 4, half-maximal inhibitory concentration: > 100 nM
Compound 4: no number, only a limit; the forecaster's own chance of this, stated with the estimate: 45%; the middle value is on the limit's open side.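

With bromo in place of chloro on an aromatic carbon, ortho to an acetamido group, compound 4 gives > 100 nM in this assay, which is a limit. The steps to compound 4 from compound 2 and from compound 3 cannot be read, so this exchange at this position gains no size, and the limit of compound 4 is the one already held by compound 3: the limit of > 100 nM in this assay, at which 2 of the 4 values shown sit.

Among the compounds shown here, what the earlier compounds did not show is a readable step with the bromo kept in place: an at least 100-fold higher number from compound 1 to compound 4 (2.00 log units; beyond the scatter), with acetyl in place of hydrogen on a nitrogen on an aromatic ring, a large step beyond the scatter.

On these data alone, how far the true values of compound 3 and compound 4 lie past their shared limit stays open, and with it any order between chloro and bromo. Also open, as far as these compounds go, is how the free amine would read with chloro, methyl or fluoro at this position, and how a longer chain than acetyl on the nitrogen would read.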